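A few compounds are considered here, and "the series" means these few. Any claim that something is new, unique, unknown or untested is made for them only; others in the source may bear on it.

Measured compounds:
Compound 1 `COc1cc(-c2nn(-c3cccc(NC(=O)Nc4cc(C(F)(F)F)cc(C(F)(F)F)c4)c3)cc2-c2ccncc2)ccc1Cl` — 2130 nM
Compound 2 `O=C(Nc1cccc(-n2cc(-c3ccncc3)c(-c3ccc(Cl)c(O)c3)n2)c1)Nc1cc(C(F)(F)F)cc(C(F)(F)F)c1` — 1690 nM
Compound 3 `COc1cc(-c2nn(-c3cccc(NC(=O)Nc4ccc(Cl)c(C(F)(F)F)c4)c3)cc2-c2ccncc2)ccc1Cl` — 16700 nM

In a functional assay on A549 cells (Homo sapiens) for inhibition, read by sulforhodamine B assay, with a stated time of 48 h (on this read-out higher numbers stand for weaker inhibition of growth and lower numbers for stronger inhibition of growth), compound 1 gives 2130 nM and compound 2 gives 1690 nM. The two differ only by hydrogen in place of methyl on an oxygen on an aromatic ring, and that change made a 1.3-fold lower number from compound 1 to compound 2 (0.10 log units; within the scatter). Compound 3 stands apart: in this assay compound 3 gives 16700 nM, the highest of the three numbers, and the difference between its core and the core of compound 1 is not broken down here.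

Compound 4 `O=C(Nc1cccc(-n2cc(-c3ccncc3)c(-c3ccc(Cl)c(O)c3)n2)c1)Nc1ccc(Cl)c(C(F)(F)F)c1` has not yet been measured in this assay. For the measured compounds named here, it differs from compound 3 by hydrogen in place of methyl on an oxygen on an aromatic ring, which is the same change, at the same place, as the one that separates compound 1 from compound 2. The step from compound 3 to compound 4 is therefore expected to be a 1.3-fold lower number from compound 3 to compound 4 (0.11 log units; within the scatter), an expectation that rests on the earlier step of a 1.3-fold lower number from compound 1 to compound 2 (0.10 log units; within the scatter), which stayed within the scatter. On that basis compound 4 is estimated at 13000 nM, with a likely range from 5000 nM to 35000 nM, so that compound 4 is expected to remain close to compound 3.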

Compound 4, concentration for total growth inhibition: 5090 nM
Compound 4: middle estimate off by 2.6-fold (0.41 log units), on the high side; measured number inside the range.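

Replacing methoxy with hydroxy on the core of compound 3 gave a 3.3-fold lower number from compound 3 to compound 4 (0.52 log units; beyond the scatter) in this assay, so on this core the change has an effect that stands clear of the usual variation between repeats. Set beside the earlier step, the new one cannot be told apart from it, which means the data give no sign that the size of the change depends on the core: the same change on two cores in this assay, a 1.3-fold lower number (0.10 log units; within the scatter) from compound 1 to compound 2 and a 3.3-fold lower number (0.52 log units; beyond the scatter) from compound 3 to compound 4, 2.6-fold (0.42 log units) apart, within the scatter of two such steps

For the compounds shown here, this does not show that the step has a fixed size or that it will exceed the scatter on a further core, since only two pairs bear on it and the step on the core of compound 1 stayed within the scatter.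

The compounds shown leave open how an amine or an ethoxy group would read in place of the methoxy of 4-chloro-3-methoxyphenyl. They also leave open whether the step would hold on a core carrying a third substitution pattern on the far aromatic ring, or in any other read-out.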